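Amide substituent on the shared core: cyclohexylamino variant

The source may hold more compounds than are shown below. What is called first, only, known or untested is meant among the compounds shown, and "the series" means these compounds.

Among the measured compounds shown here, compound 1 `COc1cc2c(cc1OC)C(CC(=O)N(C)C)CC2` gives 22.6% in a functional assay on the whole organism (strain Swiss albino) for inhibition, with Mus musculus as the target, in the writhing test, with stated times of 60 min and 15 min, at a dose of 100 mg/kg by the oral route (on this read-out lower numbers stand for less inhibition and higher numbers for more inhibition at the one dose given (going by the name of the read-out)), the lower of the two numbers measured so far; compound 2 `CCCCCNC(=O)CC1CCc2cc(OC)c(OC)cc21` gives 71.7%. For the measured compounds named here, the one measured step, a number 49.1 percentage points higher from compound 1 to compound 2 (beyond the scatter), goes with pentylamino in place of dimethylamino on a carbonyl carbon. Compound 3 `COc1cc2c(cc1OC)C(CC(=O)NC1CCCCC1)CC2` differs from compound 1 by cyclohexylamino in place of dimethylamino on a carbonyl carbon. Both changes replace dimethylamino with a group carrying one hydrogen-bond donor, so a rise beyond the scatter is expected in this assay, though cyclohexylamino is not pentylamino and the size is uncertain. Compound 3 is expected to reach 60% (range 40% to 80%). The expected step is a number 37.4 percentage points higher from compound 1 to compound 3 (beyond the scatter).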

Compound 3, a percentage reported as inhibition, in the whole organism at one dose (the size of the read-out at that dose, not a potency): 44.7%
For compound 3 the middle estimate is 15.3 percentage points above the measured one; the measured number falls inside the stated range.
By their numbers in this assay, from the lowest: compound 1; then compound 3; then compound 2.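

In this assay cyclohexylamino on the carbonyl carbon also goes with a higher number than dimethylamino (a number 22.1 percentage points higher from compound 1 to compound 3 (beyond the scatter)), so the rise is not confined to pentylamino. The two groups carrying the amide hydrogen are not equivalent: cyclohexyl in place of pentyl on an amide-type nitrogen goes with a fall (a number 27 percentage points lower from compound 2 to compound 3 (beyond the scatter)). No evidence on the cause of either step is available.

These compounds cannot separate the amide hydrogen from the size of the group, a question that methylamino would address. As far as these compounds go, how a longer chain such as heptylamino, or a benzylamino group, would stand also remains open.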